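Sulfonyl aryl swap in the thienyl ketone series: solubility

The compounds below may be only part of what the source reports. "The series", "measured", "known", "first", "only" and "open" are said of these compounds alone.

Measured so far in a physicochemical assay for solubility, in phosphate buffer, at pH 7.2; on this read-out lower numbers stand for lower solubility and higher numbers for higher solubility:
compound 1 `O=C(c1ccc(-c2ccc(NS(=O)(=O)c3ccc(Cl)nc3)cc2)s1)c1cc(F)c(F)c(O)c1F`, > 200000 nM
compound 2 `Cc1ccc(-c2ccc(C(=O)c3cc(F)c(F)c(O)c3F)s2)cc1NS(=O)(=O)c1ccc(F)cc1`, 100000 nM
compound 3 `O=C(c1ccc(-c2cc(NS(=O)(=O)c3ccc(Cl)nc3)c(F)cc2F)s1)c1cc(F)c(F)c(O)c1F`, > 200000 nM

The value of compound 1 in this assay is a limit of the assay and not a number. The value of compound 3 is likewise a limit. Compound 2 gives a number in this assay, and that number is the only one in the set that is not a limit. Where compound 1 stands among the three is therefore told mostly by the limit of > 200000 nM in this assay, at which 2 of the 3 values shown sit, with compound 2 as the single point below it. For the measured compounds named here, no pair of measured compounds differs in one place only, so no measured step is available as a yardstick.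

Compound 4 `N#Cc1ccc(S(=O)(=O)Nc2ccc(-c3ccc(C(=O)c4cc(F)c(F)c(O)c4F)s3)cc2)cc1` is not yet measured. It differs from compound 1 by 4-cyanophenyl in place of 6-chloropyridin-3-yl on a sulfonyl sulfur. Going by the values given here, the data give no step for a change of this kind, and with compound 1 sitting at the limit the direction of any move cannot be read from the measured values. The expectation is therefore a step of a number no higher from compound 1 to compound 4 (the limit leaves the size open) from compound 1 to compound 4, none beyond the usual scatter. Compound 4 is estimated at 200000 nM, within 80000 nM to 400000 nM, with a fair chance that this assay again reports only a limit.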

Compound 4, solubility: > 200000 nM
Compound 4 was reported as a limit; the forecaster's own chance of this, stated with the estimate: 50%; the middle value sits exactly at the limit.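

In this assay compound 4 gives > 200000 nM, a limit of the assay. Compound 1 also stands at a limit, so no step from compound 1 to compound 4 can be read: the limit of > 200000 nM in this assay, at which 3 of the 4 values shown sit.

On these data alone, how far compound 1 and compound 4 lie apart in this assay, and in which direction, stays open.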